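The compounds below may be only part of what the source reports. "The series", "measured", "known", "first", "only" and "open" are said of these compounds alone.

Measured in an assay on isolated protein for binding affinity to Adrenergic receptor alpha-1 (Rattus norvegicus), read by radioligand binding, in the presence of a further agent that is not named here; a higher number here means a weaker inhibitor, a lower number a stronger inhibitor:

compound 1, `C1=NCC(CC2=Cc3ccccc3CC2)N1`, gives 398 nM
compound 2, `Fc1ccc2c(c1)C=C(CC1CN=CN1)CC2`, gives 251 nM
compound 3, `C1=NCC(CC2Cc3ccccc3C2)N1`, gives 501 nM

The first two share a core and differ by fluoro in place of hydrogen on an aromatic carbon. That change gives a 1.6-fold lower number from compound 1 to compound 2 (0.20 log units; within the scatter), a step that stays within the usual scatter, so the two numbers cannot be told apart with confidence. Compound 3 stands on a different core; how the two cores differ is not broken down here. Its value in this assay sits within the scatter of compound 1 and of compound 2, so no order among the three can be claimed.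

Compound 4, `Fc1cccc2c1CC(CC1CN=CN1)C2`, has not yet been measured. It differs from compound 3 by fluoro in place of hydrogen on an aromatic carbon, the same kind of change as that from compound 1 to compound 2, though not the same: there the fluoro sits meta to a fused ring and para to a fused ring, here ortho to a fused ring and meta to a fused ring. Because the earlier change gave a 1.6-fold lower number from compound 1 to compound 2 (0.20 log units; within the scatter), the step from compound 3 to compound 4 is expected to be small, estimated at a 1.3-fold lower number from compound 3 to compound 4 (0.10 log units; within the scatter). Compound 4 is therefore estimated at 400 nM in this assay, expected to fall between 160 nM and 1000 nM.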

Compound 4, inhibition constant: 158 nM
For compound 4 the middle estimate is 2.5-fold (0.40 log units) above the measured one; measured number below the stated range.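

In this assay, fluoro in place of hydrogen on an aromatic carbon gives a 3.2-fold lower number from compound 3 to compound 4 (0.50 log units; beyond the scatter), so on the core of compound 3 the change has a readable effect. Set beside the earlier step, the new one cannot be told apart from it, and the change carries from one core to the other without a detectable difference in size: the same change on two cores in this assay, a 1.6-fold lower number (0.20 log units; within the scatter) from compound 1 to compound 2 and a 3.2-fold lower number (0.50 log units; beyond the scatter) from compound 3 to compound 4, 2.0-fold (0.30 log units) apart, within the scatter of two such steps. This does not show that the step has a fixed size across cores, since only the second step lies beyond the scatter and the place of the fluoro differs along with the core, so the two steps cannot separate core from place.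

The compounds shown leave open whether fluoro on other aromatic carbons of either core would give a similar step. They also leave open whether chloro, methoxy or a nitrile on these carbons would move the number in the same way.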